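The source may hold more compounds than are shown below. What is called first, only, known or untested is meant among the compounds shown, and "the series" means these compounds.

Working notes on the series. Among the measured compounds shown here, compound 2 `Cn1c(=O)n(C)c2c(Oc3ccc(NC(=O)Nc4cc(C(C)(C)C)nn4-c4ccccc4)c(F)c3)ccnc21` is the better of the two measured members in an in vivo ADME assay on the whole organism (strain BALB/cAnNCrl) for pharmacokinetics, with Mus musculus as the target, at a dose of 10 mg/kg by the oral route; a higher number here means that a larger share of the oral dose reaches the circulation, a lower number that a smaller share of the oral dose reaches the circulation: compound 2 gives 59%. For the measured compounds named here, compound 1 `Cc1ccc(-n2nc(C(C)(C)C)cc2NC(=O)Nc2ccc(Oc3ccnc4c3[nH]c(=O)n4C)cc2F)cn1` is the only other measured compound, and in this assay compound 1 gives 17%, a gap beyond the scatter; compound 1 differs from compound 2 in more than one place, so no single change accounts for the gap.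

Compound 3 `Cc1ccc(-n2nc(C(C)(C)C)cc2NC(=O)Nc2ccc(Oc3ccnc4c3n(C)c(=O)n4C)cc2F)cc1` differs from compound 2 in one place: methyl in place of hydrogen on an aromatic carbon. Going by the values given here, no measured pair shows this change alone, so its effect has to be guessed from the two numbers at hand. Compound 1, the weaker of the two in this assay, also carries a methyl on a six-membered aromatic ring, but with a ring nitrogen as well, so it is only a loose pointer. A moderate fall is expected from compound 2 to compound 3, with the direction uncertain and a wide spread allowed.

Compound 3 is therefore estimated at 40% in this assay, with a range from 15% to 70%; this corresponds to an expected step of a number 19 percentage points lower from compound 2 to compound 3 (beyond the scatter).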

Compound 3, oral bioavailability: 31%
Compound 3: the middle estimate sits 9 percentage points above what was measured; the range from low to high includes it.
By their numbers in this assay, from the lowest: compound 1; then compound 3; then compound 2.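

Among the compounds shown here, the change from phenyl to 4-methylphenyl is the first single-place comparison, and in this assay it gives a number 28 percentage points lower from compound 2 to compound 3 (beyond the scatter) as the only difference between the two structures. This shows that the aromatic carbon para to a large group is not a silent position in this assay: one added methyl, a single carbon with no hydrogen-bond donor or acceptor, is enough to produce a step beyond the scatter, and the direction is downward for this pair. Nothing at hand explains the step, so it stands as an observation about one pair and not as a rule for the series.

The compounds shown leave open whether the fall tracks the size of the group at this place, since only hydrogen and methyl are compared there, and an ethyl group, a methoxy group or a chlorine atom would test that reading. They also leave open whether the same change on the core of compound 1 would give a step of similar direction and size, and whether a carboxylic acid or an amine at this carbon would move the number the other way.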